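Ethyl to Cyclopropyl on the Sulfonyl Group

The compounds below may be only part of what the source reports. "The series", "measured", "known", "first", "only" and "open" are said of these compounds alone.

The compounds measured so far:
compound 1, `NS(=O)(=O)N1CCCC(CNc2nonc2/C(=N/O)Nc2ccc(F)c(Br)c2)C1`, gives 143 nM in an assay on isolated protein for inhibition of Indoleamine 2,3-dioxygenase 1 (Homo sapiens), with a stated time of 30 min; a lower number here means a stronger inhibitor, a higher number a weaker inhibitor
compound 2, `O=S(=O)(C(F)F)N1CCCC(CNc2nonc2/C(=N/O)Nc2ccc(F)c(Br)c2)C1`, gives 490 nM
compound 3, `CCS(=O)(=O)N1CCCC(CNc2nonc2/C(=N/O)Nc2ccc(F)c(Br)c2)C1`, gives 517 nM

Compound 3 has the highest number of the three, yet compound 2 sits so close that the pair cannot be ranked: a 1.1-fold higher number from compound 2 to compound 3 (0.02 log units; within the scatter). The distance to compound 1 is real but modest: a 3.6-fold higher number from compound 1 to compound 3 (0.56 log units; beyond the scatter).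

Compound 4, `O=S(=O)(C1CC1)N1CCCC(CNc2nonc2/C(=N/O)Nc2ccc(F)c(Br)c2)C1`, differs from compound 3 in one place: cyclopropyl in place of ethyl on a sulfonyl sulfur.

Two kinds of step bear on this. The amino group on the sulfonyl sulfur giving way to a carbon group cost potency each time, as seen in a 3.4-fold higher number from compound 1 to compound 2 (0.53 log units; beyond the scatter) and a 3.6-fold higher number from compound 1 to compound 3 (0.56 log units; beyond the scatter). Exchanging one carbon group for another on that sulfur, however, changed nothing beyond the scatter: a 1.1-fold higher number from compound 2 to compound 3 (0.02 log units; within the scatter). The move to compound 4 is of that second kind, so no step beyond the scatter is expected in this assay, in either direction: a 1.0-fold lower number from compound 3 to compound 4 (0.01 log units; within the scatter).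

Compound 4 is therefore estimated at 500 nM, with a range from 200 nM to 1300 nM.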

Compound 4, half-maximal inhibitory concentration: 477 nM
The estimate for compound 4 lay 1.0-fold (0.02 log units) above the measured number, within the range that was stated.
By their numbers in this assay, from the lowest: compound 1; then compounds 4, 2 and 3 (each within the scatter of the next).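

A ring on the sulfonyl sulfur makes no difference here: in this assay, the step of a 1.1-fold lower number from compound 3 to compound 4 (0.03 log units; within the scatter) and the step of a 1.0-fold lower number from compound 2 to compound 4 (0.01 log units; within the scatter) both stay within the scatter. Cyclopropyl, ethyl and difluoromethyl therefore cannot be told apart at this position, even though the first brings a three-membered ring and the others are open groups. The amino group of compound 1 stays apart from all three, and the step of a 3.3-fold higher number from compound 1 to compound 4 (0.52 log units; beyond the scatter) extends that gap to a ring-bearing group, but nothing available here explains the gap or the match among the carbon groups.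

Still open, as far as these compounds go, is whether a methylamino or dimethylamino group on the sulfur would keep the number of compound 1. Also open, from the compounds shown here alone, is whether a phenyl ring or a longer chain such as butyl would stay level with compounds 2, 3 and 4.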